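The compounds below may be only part of what the source reports. "The series", "measured", "known", "first", "only" and "open" are said of these compounds alone.

Measured in an assay on isolated protein for inhibition of Polyunsaturated fatty acid 5-lipoxygenase (Homo sapiens) (on this read-out lower numbers stand for stronger inhibition and higher numbers for weaker inhibition), so far:
compound 1 `CCOC(=O)c1c(NC(C)c2ccccc2)[nH]c2ccc(O)cc12`: 1200 nM
compound 2 `CCOC(=O)c1c(Nc2cccc(Cl)c2)[nH]c2ccc(O)cc12`: 2400 nM

Compound 1 stands at 1200 nM in this assay, with compound 2 at 2400 nM; the step of a 2.0-fold higher number from compound 1 to compound 2 (0.30 log units; within the scatter) does not separate the two. Compound 3 `CCOC(=O)c1c(NC(C)c2ccccc2)[nH]c2ccccc12` differs from compound 1 by hydrogen in place of hydroxy on an aromatic carbon. Among the measured compounds shown here, no measured step touches this position: the single step, a 2.0-fold higher number from compound 1 to compound 2 (0.30 log units; within the scatter), concerns the group on the nitrogen and says nothing about the hydroxy. For compound 3 the step of a 2.5-fold higher number from compound 1 to compound 3 (0.40 log units; beyond the scatter) is therefore expected with wide uncertainty. Compound 3 is estimated at 3000 nM, between 800 nM and 12000 nM.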

Compound 3, half-maximal inhibitory concentration: 9700 nM
Compound 3: the middle estimate sits 3.2-fold (0.51 log units) below what was measured; measured number inside the range.
By their numbers in this assay, from the lowest: compounds 1 and 2 (each within the scatter of the next); then compound 3.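

Hydrogen in place of hydroxy on this aromatic carbon gives an 8.1-fold higher number from compound 1 to compound 3 (0.91 log units; beyond the scatter) in this assay and is the first single change in the series to lie beyond the scatter. The hydroxy position therefore affects the read-out in this pair, at least with 1-phenylethyl on the nitrogen. Nothing available explains the size of this step. Open, on these data alone, is how a methoxy or an amine on the same aromatic carbon would compare with hydroxy. Also open, as far as these compounds go, is whether the step holds with 3-chlorophenyl on the nitrogen.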